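The source may hold more compounds than are shown below. What is called first, only, known or untested is meant among the compounds shown, and "the series" means these compounds.

Compound 1 `CC(C)Cc1ccc(C(=O)/C=C/c2ccc(C(=O)O)cc2)cc1` was tested in an ADME assay on Vero cells (Chlorocebus sabaeus) for cytotoxicity, read by MTT assay, with a stated time of 72 h; on this read-out higher numbers stand for lower toxicity in this test and lower numbers for higher toxicity in this test. In this assay compound 1 gives only a limit, < 10 ug/mL. Compound 2 `COC(=O)c1cc(-c2cccc(NC(=O)c3ccc(/C=C/C(=O)c4ccc(OC)cc4)cc3)c2)on1` likewise gives only a limit in this assay, > 10 ug/mL. Compound 3 `COC(=O)c1cc(-c2cccc(NC(=O)c3ccc(/C=C/C(=O)c4cc(F)ccc4F)cc3)c2)on1` also gives only a limit in this assay, > 40 ug/mL, so it stands on a limit, as do the two other values shown. The step that the two limits leave unreadable from compound 2 to compound 3 stays unreadable because the limit of > 10 ug/mL in this assay, at which 1 of the 3 values shown sits, and the limit of > 40 ug/mL in this assay, at which 1 of the 3 values shown sits, are limits rather than numbers.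

Compound 4 `COC(=O)c1cc(-c2cccc(NC(=O)c3ccc(/C=C/C(=O)c4ccccc4C)cc3)c2)on1` differs from compound 3 by 2-methylphenyl in place of 2,5-difluorophenyl on a carbonyl carbon. Going by the values given here, the only measured step at this carbonyl-borne ring, from compound 2 to compound 3, cannot be sized, so no step beyond the scatter is expected in this assay. Compound 4 is therefore estimated at 40 ug/mL, between 15 ug/mL and 100 ug/mL. The expected step is a number no higher from compound 3 to compound 4 (the limit leaves the size open).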

Compound 4, half-maximal cytotoxic concentration: > 25 ug/mL
Compound 4 gave a limit, no number (the forecaster's own chance of this, stated with the estimate: 60%); the middle value lies beyond the limit too.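

In this assay, going by these compounds alone, compound 2, compound 3 and compound 4 all give limits, not numbers, so no step among them can be read. The compounds shown leave open whether the aromatic ring on the carbonyl carbon shifts the half-maximal cytotoxic concentration, and by how much.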